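The source may hold more compounds than are shown below. What is called first, only, known or untested is meant among the compounds shown, and "the series" means these compounds.

Measured compounds in a physicochemical assay for lipophilicity; a lower number here means a more polar compound, a higher number a more lipophilic compound:
compound 1 `CC(OCn1cc[n+](C)c1/C=N/O)C(C)S(C)(=O)=O`: -2.09; -2.79 (2 entries)
compound 2 `C[n+]1ccn(CCOCCS(C)(=O)=O)c1/C=N/O`: < -3
compound 3 `CCN(CC)CCCn1cc[n+](C)c1/C=N/O`: -2.78

Within the data shown here, compound 3 is the only member of the series with a single number in this assay. Compound 1 has been run more than once, and its entries the several entries of compound 1 in this assay, -2.09; -2.79 (2 entries) lie on both sides of the value of compound 3, so the two compounds cannot be ordered. The value of compound 2 is a limit of the assay and not a number. Across the three, compound 3 sits between the upper entry of compound 1 and the limit (the limit of < -3 in this assay, at which 1 of the 3 values shown sits), with no measured step of the series pointing in either direction from it.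

Compound 4 `CCN(CCCn1cc[n+](C)c1/C=N/O)S(C)(=O)=O` is not yet measured. It differs from compound 3 by methylsulfonyl in place of ethyl on an amine nitrogen. Among the measured compounds shown here, no pair of measured compounds carries this change, so no measured step can be carried over. The expectation is that the step from compound 3 to compound 4, a number 0.08 log units higher from compound 3 to compound 4 (within the scatter), stays within the usual scatter of this assay, with no clear direction. For compound 4 the estimate in this assay is -2.7, expected to fall between -3.3 and -2.1. Since compound 2 reports only a limit (the limit of < -3 in this assay, at which 1 of the 3 values shown sits), a limit for compound 4 is also possible.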

Compound 4, distribution coefficient: -2.69
The estimate for compound 4 lay 0.01 log units below the measured number, within the range that was stated.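

In this assay, the series now has its first measured step at a single position: a number 0.09 log units higher from compound 3 to compound 4 (within the scatter). At this amine nitrogen, whose other neighbours are saturated chain carbons, methylsulfonyl in place of ethyl therefore leaves no readable difference, even though the group that enters carries hydrogen-bond acceptors and the group that leaves carries none. The repeated entries of compound 1 spread more widely than this step, which limits how much weight a single pair can carry in this assay: the several entries of compound 1 in this assay, -2.09; -2.79 (2 entries)

On these data alone, whether the same holds for other groups on this nitrogen, such as an acetyl group, a longer alkyl chain or a carboxylic acid, remains open. Among these compounds, with only one pair available, it is also open whether methylsulfonyl in place of ethyl would read the same way with a shorter or longer chain linking this nitrogen to the core of compound 3.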